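Benzyl Group Exchange on an Amide Series

The compounds below may be only part of what the source reports. "The series", "measured", "known", "first", "only" and "open" are said of these compounds alone.

Compound 1, `COC(=O)/C=C/c1cccc(N(Cc2ccc(/C=C/c3ccccn3)cc2)C(=O)C2CCCCC2)c1`: 309 nM in an assay on isolated protein with Bile acid receptor (Homo sapiens) as the target; on this read-out higher numbers stand for an effect only at larger amounts of compound and lower numbers for an effect already at smaller amounts.
Compound 2, `COC(=O)/C=C/c1cccc(N(C)C(=O)C2CCCCC2)c1`: > 1000 nM in this assay, a limit of the assay.
Compound 3, `COC(=O)/C=C/c1cccc(N(Cc2ccc(Br)cc2)C(=O)C2CCCCC2)c1`: > 1000 nM in this assay, a limit of the assay.

Compound 3 stands at the limit of this assay, not at a number, and compound 2 sits at that same limit; only compound 1 gives a number, and it is the lowest of the three. The step of an at least 3.2-fold higher number from compound 1 to compound 3 (0.51 log units; beyond the scatter) is therefore read against (the limit of > 1000 nM in this assay, at which 2 of the 3 values shown sit). The step that the two limits leave unreadable from compound 2 to compound 3 gives no size, since both of its ends are limits.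

Compound 4, `COC(=O)/C=C/c1cccc(N(Cc2cc(OC)cc(OC)c2)C(=O)C2CCCCC2)c1`, differs from compound 3 by 3,5-dimethoxyphenyl in place of 4-bromophenyl on a saturated chain carbon bound to an amide-type nitrogen. Going by the values given here, no measured step exchanges one group for another at this place; the only step touching it, a step that the two limits leave unreadable from compound 2 to compound 3, is unreadable, and an at least 3.2-fold higher number from compound 1 to compound 3 (0.51 log units; beyond the scatter) concerns a different part of the molecule. Among the compounds with values here, with compound 3 already at the limit and nothing among the measured steps pointing to a return to a readable number, the expected step that the limit leaves unreadable from compound 3 to compound 4 is small and most likely ends at the limit again. Compound 4 is accordingly estimated at 1500 nM, with a range from 500 nM to 5000 nM, and a fair chance that this assay again reports only a limit.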

Compound 4, half-maximal effective concentration: 606 nM
The estimate for compound 4 lay 2.5-fold (0.39 log units) above the measured number; low and high end bracket the measured number.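

Going by these compounds alone, the place on the saturated chain carbon bound to an amide-type nitrogen now gives a readable number with a much smaller group: until this result only compound 1, which carries the 2-(pyridin-2-yl)ethenyl group, had given one, and in this assay compound 4 gives 606 nM. Exchanging 4-bromophenyl for 3,5-dimethoxyphenyl gives an at least 1.6-fold lower number from compound 3 to compound 4 (0.21 log units; that floor lies within the scatter), and 3,5-dimethoxyphenyl in place of hydrogen gives an at least 1.6-fold lower number from compound 2 to compound 4 (0.21 log units; that floor lies within the scatter). So the 2-(pyridin-2-yl)ethenyl group is not needed for a number in this assay, but the true size of both steps remains unknown, as each is a floor that lies within the scatter and each starts from a limit: the limit of > 1000 nM in this assay, at which 2 of the 4 values shown sit.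

The compounds shown do not tell whether both methoxy groups are needed, or whether a phenyl ring with a single methoxy group, or with hydroxy groups in their place, would behave the same way. They also leave open how the 3,5-dimethoxyphenyl group would fare with a carboxylic acid in place of the methyl ester on the shared core.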